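This account rests on a few compounds, and the source may have more. Where it says the series, first, only, none or still open, it means among the compounds named here.

Compound 1 `O=C(/N=C(/NC(=O)c1cc(-c2ccccc2)nc2ccccc12)[Se]Cc1ccccc1)c1cc(-c2ccccc2)nc2ccccc12` and compound 2 `C[Se]/C(=N\C(=O)c1cc(-c2ccccc2)nc2ccccc12)NC(=O)c1cc(-c2ccccc2)nc2ccccc12` share one core and differ only in hydrogen in place of phenyl on a saturated chain carbon bound to a selenium atom. In a functional assay on K562 cells (Homo sapiens) for cytotoxicity, read by MTT assay, with a stated time of 72 h (on this read-out higher numbers stand for lower toxicity in this test and lower numbers for higher toxicity in this test), compound 1 gives 88900 nM, and compound 2 gives 73100 nM; the step of a 1.2-fold lower number from compound 1 to compound 2 (0.08 log units; within the scatter) is the only one so far for this change. Compound 3 `O=C(/N=C(/NC(=O)c1csc([N+](=O)[O-])c1)[Se]Cc1ccccc1)c1csc([N+](=O)[O-])c1` carries a different core; how the two cores differ is not broken down here. In this assay compound 3 gives 88200 nM. Compound 4 `C[Se]/C(=N\C(=O)c1csc([N+](=O)[O-])c1)NC(=O)c1csc([N+](=O)[O-])c1` is compound 3 altered by hydrogen in place of phenyl on a saturated chain carbon bound to a selenium atom, the same change as that from compound 1 to compound 2. Because the step of a 1.2-fold lower number from compound 1 to compound 2 (0.08 log units; within the scatter) was within the scatter, the step from compound 3 to compound 4 in this assay is expected to be small, about a 1.2-fold lower number from compound 3 to compound 4 (0.07 log units; within the scatter). For compound 4 in this assay the estimate is 75000 nM, with a range from 42000 nM to 135000 nM.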

Compound 4, concentration lethal to 50% of the cells: > 100000 nM
Compound 4: no number, only a limit; the forecaster's own chance of this, stated with the estimate: 10%; middle value at least 1.3-fold (0.12 log units) away from the limit.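

In this assay compound 4 carries a limit of the assay and not a number: the limit of > 100000 nM in this assay, at which 1 of the 4 values shown sits. Going from benzyl to methyl on the core of compound 3 gives an at least 1.1-fold higher number from compound 3 to compound 4 (0.05 log units; that floor lies within the scatter), and set beside the earlier step this reads: the same change on two cores in this assay, a 1.2-fold lower number (0.08 log units; within the scatter) from compound 1 to compound 2 and an at least 1.1-fold higher number (0.05 log units; that floor lies within the scatter) from compound 3 to compound 4; the limit leaves it open whether they differ. The change therefore stays within the scatter on the core of compound 1, while the limit on the core of compound 3 neither shows that the change carries over unaltered nor shows that it does not.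

The compounds shown leave open how a longer chain on selenium, or a chain ending in an amine or a carboxylic acid, would read. They also leave open how the change would read on a third core.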